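The compounds below may be only part of what the source reports. "The series", "measured", "known", "first", "only" and "open" are said of these compounds alone.

Compound 1 `CCC(=O)Nc1sc2c(c1C#N)CCCC2`: in a functional assay on RKE cells for antagonist activity at Vasoactive intestinal polypeptide receptor 1 (Rattus norvegicus), read by HTRF and cAMP accumulation, with stated times of 10 min and 30 min (on this read-out higher numbers stand for weaker inhibition and lower numbers for stronger inhibition), compound 1 gives 12000 nM.
Compound 2 `CC(C)c1cc(C(C)(C)C)cc(-c2cccc(C#N)c2)c1CO`: in this assay compound 2 reaches only the limit of the assay, > 50000 nM, and no number.
Compound 3 `CC(C)c1cc(C(C)(C)C)cc(-c2cccc(-c3ccccc3)c2)c1CO`: in this assay compound 3 gives 210 nM.

Of the two numbers shown, compound 1 stands at the higher one, so it is the weaker inhibitor of the two; compound 3 sits at the lower one, 210 nM, and that gap is beyond the usual scatter. Going by the values given here, the only measured step is an at least 230-fold lower number from compound 2 to compound 3 (2.37 log units; beyond the scatter), a swap on an aromatic carbon of a different core from that of compound 1. On these data alone, its starting point is only a limit, (the limit of > 50000 nM in this assay, at which 1 of the 3 values shown sits), so its true size is unknown beyond being large.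

Compound 4 `CC(C)C(=O)Nc1sc2c(c1C#N)CCCC2` differs from compound 1 by methyl in place of hydrogen on a saturated chain carbon bound to a carbonyl carbon and a saturated chain carbon. Among the compounds with values here, no measured step touches the amide chain or anything like it, so nothing among the measured compounds speaks for a change in either direction. The expectation is therefore a step of no size beyond the scatter, no change at the digits printed from compound 1 to compound 4 (within the scatter). In this assay compound 4 is estimated at 12000 nM, with a likely range from 4000 nM to 40000 nM.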

Compound 4, half-maximal inhibitory concentration: 3400 nM
The estimate for compound 4 lay 3.5-fold (0.55 log units) above the measured number, and the stated range ends above it.
By their numbers in this assay, from the lowest: compound 3; then compound 4; then compound 1. At a limit, above all of these: compound 2.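

The amide chain of the shared core responds to even a small change: going from ethyl to isopropyl gives a 3.5-fold lower number from compound 1 to compound 4 (0.55 log units; beyond the scatter) in this assay, with a single added carbon as the only difference. Going by these compounds alone, this is the first measured step on this core, and it shows that a methyl in place of hydrogen on this saturated chain carbon, bound to a carbonyl carbon and a saturated chain carbon, is accepted and here goes with stronger inhibition. A single pair gives a direction for this one change, but no rule for the chain as a whole, and nothing at hand bears on the reason for this step.

On these data alone, it remains open whether further growth at this carbon, as in a tert-butyl group, a cyclopropyl ring or a longer chain such as butanoyl, would lower the number again or reverse the change. Also open, as far as these compounds go, is how an amine or a carboxylic acid on this chain would fare, and whether the nitrile on the core of compound 4 can be replaced by another group, such as an amide or an ester.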